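A few compounds are considered here, and "the series" means these few. Any claim that something is new, unique, unknown or untested is made for them only; others in the source may bear on it.

Measured so far in a functional assay on HEK293 cells for antagonist activity at transient receptor potential cation channel subfamily V member 1 (Homo sapiens), read by calcium flux; a higher number here means a weaker inhibitor, a lower number a stronger inhibitor:
compound 1 `FC(F)(F)c1ccc(Nc2ncnc3sc(Nc4c(Cl)cccc4Cl)nc23)cc1` gives 12 nM
compound 2 `FC(F)(F)c1ccc(Nc2ncnc3sc(Nc4ccccc4Cl)nc23)cc1` gives 64 nM
compound 3 `CS(=O)(=O)c1ccccc1Nc1nc2c(Nc3ccc(C(F)(F)F)cc3)ncnc2s1` gives 234 nM

Compound 3 stands highest of the three in this assay. Compound 2 is nearest to it, separated by a 3.7-fold higher number from compound 2 to compound 3 (0.56 log units; beyond the scatter), and compound 1 is furthest, separated by a 20-fold higher number from compound 1 to compound 3 (1.29 log units; beyond the scatter).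

Compound 4 `N#Cc1cc(Cl)c(Nc2nc3c(Nc4ccc(C(F)(F)F)cc4)ncnc3s2)c(Cl)c1` differs from compound 3 in one place: 2,6-dichloro-4-cyanophenyl in place of 2-(methylsulfonyl)phenyl on a nitrogen on an aromatic ring. The change has two parts. Among the compounds with values here, the two chloro substituents return to the arrangement seen in compound 1, and a nitrile is added, for which no measured step exists.

Within the data shown here, the steps that bear on this are a 20-fold higher number from compound 1 to compound 3 (1.29 log units; beyond the scatter), which is the same exchange run the other way without the nitrile, and the pair a 5.3-fold higher number from compound 1 to compound 2 (0.73 log units; beyond the scatter) and a 3.7-fold higher number from compound 2 to compound 3 (0.56 log units; beyond the scatter), which together show that each chloro on that ring goes with a lower number in this assay. A large decrease is therefore expected, roughly back to the level of compound 1, with the nitrile an unknown that widens the range. Compound 4 is expected at about 15 nM, within 5 nM to 60 nM, corresponding to an estimated step of a 16-fold lower number from compound 3 to compound 4 (1.19 log units; beyond the scatter).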

Compound 4, half-maximal inhibitory concentration: 95 nM
Beside the measured number, compound 4's estimate is 6.3-fold (0.80 log units) below it; measured number above the stated range.
By their numbers in this assay, from the lowest: compound 1; then compounds 2 and 4 (each within the scatter of the next); then compound 3.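

In this assay, within the data shown here, the nitrile is the single change on the 2,6-dichlorophenyl group (a 7.9-fold higher number from compound 1 to compound 4 (0.90 log units; beyond the scatter)), and this is the first reading of a substituent added to that ring rather than exchanged on it; the addition gives up much of the advantage the two chloro groups hold over the 2-(methylsulfonyl)phenyl group. Against that group, 2,6-dichloro-4-cyanophenyl keeps only a modest step (a 2.5-fold lower number from compound 3 to compound 4 (0.39 log units; beyond the scatter)), while against 2-chlorophenyl the step lies within the scatter (a 1.5-fold higher number from compound 2 to compound 4 (0.17 log units; within the scatter)), so on this nitrogen those two groups cannot be told apart. No measurement at hand accounts for the nitrile step.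

Open, from the compounds shown here alone, is whether the higher number belongs to the nitrile itself or would also come with a fluoro, a methoxy, an amine or a carboxylic acid in its place on the 2,6-dichlorophenyl group. Also open, going by these compounds, is whether a nitrile on the 2-chlorophenyl group would give a step of similar size, and whether the step would hold with a group other than trifluoromethyl on the other aromatic ring.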